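The compounds below may be only part of what the source reports. "The series", "measured", "known", "first", "only" and "open" are said of these compounds alone.

Measured compounds in a functional assay on the whole organism (strain Swiss) with Mus musculus as the target, in the maximal electroshock model, with a stated time of 0.5 h, at a dose of 300 mg/kg by the intraperitoneal route; on this read-out higher numbers stand for a stronger effect at the one dose given and lower numbers for a weaker effect:
compound 1 `CCC(C(=O)N1CCN(c2ccc(F)cc2)CC1)N1C(=O)CCC1=O` — 25%
compound 2 `CC(C(=O)N1CCN(c2ccc(F)cc2)CC1)N1C(=O)CCC1=O` — 50%

Going by the values given here, compound 1 stands lowest of the two numbers, and its only neighbour is compound 2, reached by the one measured step, a number 25 percentage points higher from compound 1 to compound 2 (beyond the scatter), which concerns hydrogen in place of methyl on a saturated chain carbon, two bonds along the chain from an amide-type nitrogen in a ring and a carbonyl carbon. Compound 3 `CCC(C(=O)N1CCN(c2cccc(Cl)c2)CC1)N1C(=O)CCC1=O` differs from compound 1 at another place altogether: 3-chlorophenyl in place of 4-fluorophenyl on an amine nitrogen in a ring. Among the compounds with values here, the ethyl chain of compound 1 is kept unchanged, so the step from compound 1 to compound 2 does not bear on this change, and no measured pair shows what swapping the group on the amine nitrogen in the ring does in this assay. The expected step is no change at the digits printed from compound 1 to compound 3 (within the scatter), which means none beyond the scatter. Compound 3 is estimated to give about 25% in this assay, with a wide range from 5% to 55%.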

Compound 3, a percentage reported as activity, at one dose (the size of the read-out at that dose, not a potency): 50%
The estimate for compound 3 lay 25 percentage points below the measured number, and the stated range covers the measured number.
By their numbers in this assay, from the lowest: compound 1; then compounds 2 and 3 (each within the scatter of the next).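

In this assay, the group on the amine nitrogen in a ring also affects the read-out: with the ethyl chain of compound 1 kept, 3-chlorophenyl in place of 4-fluorophenyl gives a number 25 percentage points higher from compound 1 to compound 3 (beyond the scatter) in a change that leaves the heavy-atom count of the group the same. Going by these compounds alone, the earlier step concerned only the saturated chain carbon, so this is the first sign that the aromatic group on this ring nitrogen can also move the number beyond the scatter. No measurement at hand explains this difference.

This single swap changes both the halogen and where it sits on the phenyl ring, so 4-chlorophenyl and 3-fluorophenyl would be needed to separate the two changes. Going by these compounds, it also remains open whether 3-chlorophenyl gives a similar step on the shorter chain of compound 2.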